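Urea series: substituent at the aromatic position

The source may hold more compounds than are shown below. What is called first, only, known or untested is meant among the compounds shown, and "the series" means these compounds.

Measured so far:
compound 1 `O=C(Nc1cccc2[nH]ncc12)NC1CCc2cc(Br)ccc21`, 9 nM
compound 2 `O=C(Nc1cccc2[nH]ncc12)NC1CCc2ccccc21`, 151 nM
compound 3 `O=C(Nc1cccc2[nH]ncc12)NC1CCc2cc(C(F)(F)F)ccc21`, 3 nM

Compound 3 gives the lowest number of the three in an assay on isolated protein for inhibition of transient receptor potential cation channel subfamily V member 1 (Homo sapiens), read by calcium flux; on this read-out higher numbers stand for weaker inhibition and lower numbers for stronger inhibition; its nearest neighbour is compound 1, with a 3.0-fold lower number from compound 1 to compound 3 (0.48 log units; beyond the scatter), and the furthest is compound 2, with a 50-fold lower number from compound 2 to compound 3 (1.70 log units; beyond the scatter). Compound 4 `Cc1ccc2c(c1)CCC2NC(=O)Nc1cccc2[nH]ncc12` has not yet been measured. It differs from compound 3 by methyl in place of trifluoromethyl on an aromatic carbon.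

Going by the values given here, two measured steps bear on this change, both at the same aromatic carbon: the removal of the substituent, a 17-fold higher number from compound 1 to compound 2 (1.22 log units; beyond the scatter), and its replacement, a 50-fold lower number from compound 2 to compound 3 (1.70 log units; beyond the scatter). Both were large. The step from compound 3 to compound 4 keeps a substituent at that carbon but swaps to a smaller one, so a change somewhere between those two extremes is expected: a rise in the number, smaller than the gap that separates compound 2 from compound 3. The expected step is a 6.7-fold higher number from compound 3 to compound 4 (0.82 log units; beyond the scatter), beyond the scatter but not as large as the two measured steps. For compound 4 the estimate in this assay is 20 nM, with a range from 6 nM to 60 nM.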

Compound 4, half-maximal inhibitory concentration: 11 nM
Beside the measured number, compound 4's estimate is 1.8-fold (0.26 log units) above it; low and high end bracket the measured number.
By their numbers in this assay, from the lowest: compound 3; then compounds 1 and 4 (each within the scatter of the next); then compound 2.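

In this assay a third substituent at this aromatic carbon gives a large step (a 14-fold lower number from compound 2 to compound 4 (1.14 log units; beyond the scatter)), and methyl enters with a single heavy atom, so the step away from hydrogen is not confined to bromo and trifluoromethyl; among the compounds shown, none goes against this. The new result also separates the substituents only in part: methyl and bromo cannot be told apart (a 1.2-fold higher number from compound 1 to compound 4 (0.09 log units; within the scatter)), whereas trifluoromethyl keeps a modest margin over methyl (a 3.7-fold higher number from compound 3 to compound 4 (0.56 log units; beyond the scatter)), leaving compound 3 alone at the low end of the series. Nothing measured here accounts for these differences.

The compounds shown leave open whether the same holds for a methoxy group, a nitrile, an amine or a carboxylic acid at this carbon, and whether a longer chain or a tert-butyl group would continue the step seen with trifluoromethyl or lose it. From the compounds shown here alone, they also hold every substituent at one carbon of the shared core, so the effect of the same groups elsewhere on that aromatic ring remains unknown.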